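Para-fluoro analogue of compound 1 in the cytotoxicity assay

The source may hold more compounds than are shown below. What is called first, only, known or untested is meant among the compounds shown, and "the series" means these compounds.

Measured so far:
- compound 1, `C[C@@H]1CC[C@@H]2[C@@H](C1)O[C@@H](c1ccccc1)CC2(C)O`: 580000 nM
- compound 2, `C[C@@H]1CC[C@@H]2[C@@H](C1)O[C@@H](c1ccccc1O)CC2(C)O`: > 1080000 nM, a limit of the assay

In an ADME assay on MDCK cells (Canis lupus familiaris) for cytotoxicity, read by MTT assay, with a stated time of 48 h (a lower number here means that less compound is tolerated, a higher number that more compound is tolerated), compound 1 gives 580000 nM. Going by the values given here, compound 1 holds the only number in this small set; the other value is a limit. Compound 2 sits at the limit of > 1080000 nM in this assay, at which 1 of the 2 values shown sits. Among the compounds with values here, the single measured step, hydroxy in place of hydrogen on an aromatic carbon, gives an at least 1.8-fold higher number from compound 1 to compound 2 (0.26 log units; that floor lies within the scatter), so substitution on the phenyl ring of the shared core has so far not moved the read-out beyond the scatter.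

Compound 3, `C[C@@H]1CC[C@@H]2[C@@H](C1)O[C@@H](c1ccc(F)cc1)CC2(C)O`, is not yet measured. It differs from compound 1 by fluoro in place of hydrogen on an aromatic carbon. Within the data shown here, the only step that bears on it is the one from compound 1 to compound 2, which is small and whose floor lies within the scatter. On that basis no step beyond the scatter is expected for compound 3, and the estimated step is a 1.0-fold higher number from compound 1 to compound 3 (0.01 log units; within the scatter). Compound 3 is therefore expected to give about 600000 nM in this assay, with a range from 300000 nM to 1200000 nM.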

Compound 3, half-maximal cytotoxic concentration: 65000 nM
The estimate for compound 3 lay 9.2-fold (0.97 log units) above the measured number, and the stated range ends above it.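

In this assay, going by these compounds alone, the position para to a large group on the aromatic ring proves responsive: fluoro in place of hydrogen on an aromatic carbon gives an 8.9-fold lower number from compound 1 to compound 3 (0.95 log units; beyond the scatter), the first step that clearly exceeds the scatter. Within the data shown here, a single fluorine atom on the phenyl ring of the shared core is therefore enough to change how much compound is tolerated, something the earlier pair could not show, as the floor of its only step lies within the scatter. Nothing shown here accounts for the size or direction of this step.

On these data alone, it remains open whether the lower number belongs to fluoro itself or would follow from other groups in the same place; a chloro group, a methoxy group or an amine there would help separate those two readings. Among these compounds, compound 2 gives > 1080000 nM, which is a limit and not a number, so the true size of its step stays unknown and the series still has only one fully measured change.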